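Retinoid-type esters: aromatic hydroxylation pattern and fibroblast cytotoxicity

The compounds below may be only part of what the source reports. "The series", "measured", "known", "first", "only" and "open" are said of these compounds alone.

The series shares one polyene ester core and varies only the aromatic acid. Compound 1 `CC(/C=C/C1=CCCCC1(C)C)=C\C=C\C(C)=C\COC(=O)c1cccc(O)c1O` carries a 2,3-dihydroxyphenyl on the carbonyl carbon. On these data alone, in a toxicity assay on cells (Fibroblast, Homo sapiens) for cytotoxicity (a lower number here means a stronger inhibitor, a higher number a weaker inhibitor), compound 1 reaches only the limit < 10000 nM, so its true value is unknown and sits at the limit of < 10000 nM in this assay, at which 1 of the 3 values shown sits. Compound 2 `CC(/C=C/C1=CCCCC1(C)C)=C\C=C\C(C)=C\COC(=O)c1ccc(O)cc1O` gives 120000 nM and compound 3 `COc1cccc(C(=O)OC/C=C(C)/C=C/C=C(C)/C=C/C2=CCCCC2(C)C)c1O` gives 27000 nM. Both shown steps away from compound 1 weaken the effect: an at least 12-fold higher number from compound 1 to compound 2 (1.07 log units; beyond the scatter) and an at least 2.7-fold higher number from compound 1 to compound 3 (0.43 log units; beyond the scatter). Between the two weaker compounds, a 4.4-fold lower number from compound 2 to compound 3 (0.65 log units; beyond the scatter).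

Compound 4 `CC(/C=C/C1=CCCCC1(C)C)=C\C=C\C(C)=C\COC(=O)c1cc(O)c(O)c(O)c1` is not yet measured. The change from compound 1 is 3,4,5-trihydroxyphenyl in place of 2,3-dihydroxyphenyl on a carbonyl carbon. Within the data shown here, no measured step shows this exact substitution; the nearest are the repositioning of hydroxyls in an at least 12-fold higher number from compound 1 to compound 2 (1.07 log units; beyond the scatter) and the capping of one hydroxyl in an at least 2.7-fold higher number from compound 1 to compound 3 (0.43 log units; beyond the scatter), both of which moved the number upward. Since compound 1 stands only at a limit, the size of the step cannot be fixed, but the two shown moves argue against a stronger effect than compound 1.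

For compound 4 in this assay a value of 15000 nM is estimated, with a range of 5000 nM to 60000 nM, which is expected to correspond to an at least 1.5-fold higher number from compound 1 to compound 4 (0.17 log units; that floor lies within the scatter).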

Compound 4, half-maximal inhibitory concentration: 35000 nM
Compound 4: the middle estimate sits 2.3-fold (0.37 log units) below what was measured; the measured number falls inside the stated range.
By their numbers in this assay, from the lowest: compounds 3 and 4 (each within the scatter of the next); then compound 2. At a limit, below all of these: compound 1.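

Among the groups on the carbonyl carbon, 3,4,5-trihydroxyphenyl is a third replacement for 2,3-dihydroxyphenyl that raises the number in this assay, with an at least 3.5-fold higher number from compound 1 to compound 4 (0.54 log units; beyond the scatter), so all the replacements shown now move the same way. The 3,4,5-trihydroxyphenyl group cannot be told apart from 2-hydroxy-3-methoxyphenyl, with a 1.3-fold higher number from compound 3 to compound 4 (0.11 log units; within the scatter), yet it differs from 2,4-dihydroxyphenyl, with a 3.4-fold lower number from compound 2 to compound 4 (0.54 log units; beyond the scatter), so two groups carrying only free hydroxyls can sit apart and the presence of free hydroxyls alone does not set the number. Compound 1 remains a limit, so each step from it gives only a floor: the limit of < 10000 nM in this assay, at which 1 of the 4 values shown sits.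

The compounds shown leave open how far the 2,3-dihydroxyphenyl ester actually stands from the others, as a true value for compound 1 is still lacking. They also leave open whether that group keeps its standing when one hydroxyl gives way to an amine or a carboxylic acid, since every ring shown carries only hydroxyl or methoxy groups.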